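A Larger Aromatic Arm on the Shared Core

The source may hold more compounds than are shown below. What is called first, only, known or untested is meant among the compounds shown, and "the series" means these compounds.

Compound 1 `O=c1[nH]cnc2c1c(-c1cccs1)cn2[C@@H]1O[C@H](CO)[C@@H](O)[C@H]1O` was tested in a functional assay on HL-60 cells (Homo sapiens) for antiproliferative activity, read by XTT assay, with a stated time of 72 h; on this read-out higher numbers stand for weaker inhibition and lower numbers for stronger inhibition. In this assay compound 1 gives > 20000 nM, which is a limit of the assay rather than a number. Compound 3 `Nc1nc2c(c(-c3cccs3)cn2[C@@H]2O[C@H](CO)[C@@H](O)[C@H]2O)c(=O)[nH]1` differs from compound 1 by amino in place of hydrogen on an aromatic carbon. In this assay compound 3 gives > 20000 nM, again a limit. The step that the two limits leave unreadable from compound 1 to compound 3 therefore cannot be read. Compound 2 `Cc1ncnc2c1c(-c1cc3ccccc3o1)cn2[C@@H]1O[C@H](CO)[C@@H](O)[C@H]1O`, which already carries a 1-benzofuran-2-yl group on its core, gives > 20000 nM in this assay, also a limit. All three values sit at the same place, as summarised by the limit of > 20000 nM in this assay, at which 3 of the 3 values shown sit, so compound 1 stands no better or worse than its neighbours on the numbers shown.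

Compound 4 `O=c1[nH]cnc2c1c(-c1cc3ccccc3o1)cn2[C@@H]1O[C@H](CO)[C@@H](O)[C@H]1O` differs from compound 1 in one place: 1-benzofuran-2-yl in place of thiophen-2-yl on an aromatic carbon. Among the compounds with values here, no measured step speaks to this change in size or direction. Given that compound 2, bearing the same 1-benzofuran-2-yl group, gives only a limit, compound 4 is expected to give a limit as well, with an estimated 30000 nM between 10000 nM and 100000 nM, so the expected step that the limit leaves unreadable from compound 1 to compound 4 is not readable beyond the scatter.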

Compound 4, half-maximal inhibitory concentration: > 20000 nM
Compound 4: a limit, no number (the forecaster's own chance of this, stated with the estimate: 80%); the middle value does not contradict the limit.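

Within the data shown here, compound 1 and compound 4 both give a limit of the assay rather than a number, so no step between them can be read: the limit of > 20000 nM in this assay, at which 4 of the 4 values shown sit. The compounds shown leave open which change on the shared core, if any, would give a measurable value in this assay.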